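A Bromo for Fluoro Swap in a Narrow Series

The source may report more compounds than this note shows. Statements on the series, on what has been measured and on what is new or still open speak of the compounds shown alone.

In a functional assay on B16-F10 cells (Mus musculus) for antiproliferative activity, read by colorimetric assay and MTT assay, with a stated time of 48 h (a higher number here means a weaker inhibitor, a lower number a stronger inhibitor), compound 1 `O=C(NS(=O)(=O)c1ccccc1)c1cncc(C(=O)NS(=O)(=O)c2ccccc2)c1` gives 11300 nM as its half-maximal inhibitory concentration. Compound 2 `Cc1ccc(S(=O)(=O)NC(=O)c2cncc(C(=O)NS(=O)(=O)c3ccc(C)cc3)c2)cc1` gives 9200 nM in the same read-out, and compound 3 `O=C(NS(=O)(=O)c1ccc(F)cc1)c1ccncc1` gives 13800 nM there. All three numbers lie within the scatter of one another, and compound 3 stands level with the other two. Compound 4 `O=C(NS(=O)(=O)c1ccc(Br)cc1)c1ccncc1` carries bromo in place of fluoro on an aromatic carbon and keeps the same place, para to a large group. For the measured compounds named here, no measured pair here shows this kind of change. No step beyond the scatter is expected in this assay for this swap. The expected change is a 1.3-fold lower number from compound 3 to compound 4 (0.10 log units; within the scatter) and stays within the scatter. Compound 4 is estimated at 11000 nM with an expected range from 5500 nM to 22000 nM in this measurement.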

Compound 4, half-maximal inhibitory concentration: 8800 nM
For compound 4 the middle estimate is 1.3-fold (0.10 log units) above the measured one; the measured number falls inside the stated range.
By their numbers in this assay, from the lowest: compounds 4, 2, 1 and 3 (each within the scatter of the next).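

For the compounds shown here, this is the first pair that differs in one place: with bromo in place of fluoro on an aromatic carbon, para to a large group, this assay shows a 1.6-fold lower number from compound 3 to compound 4 (0.20 log units; within the scatter), which lies within the scatter. Compound 3 and compound 4 therefore stand level, and at this place the two halogens are not told apart. Nothing at hand bears on why this is so. From the compounds shown here alone, whether an amine or a carboxylic acid at this place would also stand level remains open. So does whether the same swap would give a similar result on the core of compound 1.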